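Amide in place of methoxy on the aryl group

A few compounds are considered here, and "the series" means these few. Any claim that something is new, unique, unknown or untested is made for them only; others in the source may bear on it.

Measured compounds:
compound 1 `CCCC(=O)Nc1ccc(-c2cn3c(=O)c(C(=O)OCC)cn(Cc4ccccc4F)c3n2)cc1` 30000 nM
compound 2 `CCOC(=O)c1cn(Cc2ccccc2F)c2nc(-c3ccc(OC)cc3)c(CN(C)Cc3ccccc3)n2c1=O` 950 nM

In an assay on isolated protein for agonist activity at Gonadotropin-releasing hormone receptor (Homo sapiens) (a lower number here means a stronger inhibitor, a higher number a weaker inhibitor), compound 2 gives the lower of the two numbers; compound 1 stands above it by a gap beyond the scatter. Compound 3 `CCCC(=O)Nc1ccc(-c2nc3n(Cc4ccccc4F)cc(C(=O)OCC)c(=O)n3c2CN(C)Cc2ccccc2)cc1` is compound 2 with (propylcarbonyl)amino in place of methoxy on an aromatic carbon. For the measured compounds named here, no step between measured compounds that differ in one place exists, so the size of this step is open; compound 1 carries the same amide but also lacks a second substituent present in compound 2, so its value does not isolate the amide change. A modest weakening is expected, a 2.6-fold higher number from compound 2 to compound 3 (0.42 log units; beyond the scatter). Compound 3 is estimated at 2500 nM, within 500 nM to 12000 nM.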

Compound 3, inhibition constant: 80 nM
Estimate against measurement, compound 3: 31-fold (1.49 log units) above, outside the stated range (below it).
By their numbers in this assay, from the lowest: compound 3; then compound 2; then compound 1.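

In this assay the amide change is now isolated: (propylcarbonyl)amino in place of methoxy gives a 12-fold lower number from compound 2 to compound 3 (1.07 log units; beyond the scatter) and so improves on methoxy at this aromatic carbon. With the amide held fixed, (benzyl(methyl)amino)methyl in place of hydrogen gives a 380-fold lower number from compound 1 to compound 3 (2.57 log units; beyond the scatter) and so the weak value of compound 1 says nothing against the amide. The data offer no measured explanation for either step.

As far as these compounds go, whether a longer chain or an acetyl amide would do better at this position stays open. So does the role of the amide hydrogen, which a methylated amide would test.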